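Swapping Methoxy for Fluoro on the Sulfonyl Aryl Ring

The source may hold more compounds than are shown below. What is called first, only, known or untested is meant among the compounds shown, and "the series" means these compounds.

Measured so far:
- compound 1, `COc1ccc(-c2c(S(=O)(=O)c3cc(Cl)cc(Cl)c3)cnc3c(F)cccc23)cc1`: 2.11 mL/min
- compound 2, `COc1ccc(-c2c(S(=O)(=O)c3ccc(OC)cc3)cnc3c(F)cccc23)cc1`: 2.12 mL/min

In an ADME assay on microsomes from liver (Homo sapiens) for metabolic stability, tested at 2.5 uM (on this read-out lower numbers stand for slow clearance and higher numbers for fast clearance), compound 1 gives 2.11 mL/min and compound 2 gives 2.12 mL/min, two numbers that sit inside the usual scatter of one another, so neither can be called slower or faster. Among the measured compounds shown here, the only step available, a 1.0-fold higher number from compound 1 to compound 2 (0.00 log units; within the scatter), swaps one ring on the sulfonyl sulfur for another without moving the read-out.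

Compound 3, `COc1ccc(-c2c(S(=O)(=O)c3ccc(F)cc3)cnc3c(F)cccc23)cc1`, differs from compound 2 by fluoro in place of methoxy on an aromatic carbon. For the measured compounds named here, this sits on the same sulfonyl-attached ring that was varied between compounds 1 and 2, where a larger swap produced no step. Going by the values given here, with only that step to lean on, compound 3 is expected to stay where compound 2 is, giving 2.1 mL/min, with a range of 1.1 mL/min to 4.2 mL/min. The step from compound 2 to compound 3 in this assay is therefore estimated at a 1.0-fold lower number from compound 2 to compound 3 (0.00 log units; within the scatter), nothing beyond the scatter.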

Compound 3, intrinsic clearance in a liver preparation (reported as CLH), per the amount of preparation that the assay uses: 2.41 mL/min
The estimate for compound 3 lay 1.1-fold (0.06 log units) below the measured number; the range from low to high includes it.
By their numbers in this assay, from the lowest: compounds 1, 2 and 3 (each within the scatter of the next).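

In this assay, fluoro in place of methoxy on an aromatic carbon, para to a large group, gives a 1.1-fold higher number from compound 2 to compound 3 (0.06 log units; within the scatter), so a group with one heavy atom and no hydrogen-bond acceptor reads the same as a group with two heavy atoms and one acceptor. Comparing the 4-fluorophenyl ring on the sulfonyl sulfur with 3,5-dichlorophenyl gives a 1.1-fold higher number from compound 1 to compound 3 (0.06 log units; within the scatter), which means three different rings at this place now cannot be told apart, where the earlier pair offered only two. Nothing measured here gives a reason for this flat picture.

On these data alone, whether an amine or a carboxylic acid on this ring would read the same remains open. So does whether changes elsewhere on the shared core, such as replacing the other methoxy group, would move the number.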